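The source may hold more compounds than are shown below. What is called first, only, known or untested is meant among the compounds shown, and "the series" means these compounds.

Working notes on the series. In a toxicity assay on THP-1 cells (Homo sapiens) for inhibition (a higher number here means that more compound is tolerated, a lower number that less compound is tolerated), compound 1 (`CCCC(=O)Nc1ncc(-c2ccc(OC)cc2)n1C`) gives > 100000 nM, which is a limit of the assay and not a number. Compound 2 (`COc1ccc(-c2cnc(NC(=O)c3ccccc3C#N)n2C)cc1`) gives > 100000 nM, also a limit and not a number. Compound 2 therefore has no exact position on the scale, and the picture so far is the limit of > 100000 nM in this assay, at which 2 of the 2 values shown sit.

The next compound is compound 3 (`COc1ccc(-c2cnc(NC(C)=O)n2C)cc1`), with the change (methyl in place of 2-cyanophenyl on a carbonyl carbon). In words, this is methyl in place of 2-cyanophenyl on a carbonyl carbon.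

Among the compounds with values here, only one measured step bears on this carbonyl carbon: a step that the two limits leave unreadable from compound 1 to compound 2. It offers no size to carry over, yet neither propyl on compound 1 nor 2-cyanophenyl on compound 2 gave a reading short of the limit. Methyl is therefore expected to leave this assay without a change beyond the scatter, in either direction. The expected outcome is no real shift, estimated as a number no higher from compound 2 to compound 3 (the limit leaves the size open). For compound 3 the estimate is 100000 nM, with an expected range from 50000 nM to 200000 nM, most likely reported again as a limit.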

Compound 3, half-maximal cytotoxic concentration: > 100000 nM
Compound 3: no number, only a limit (the forecaster's own chance of this, stated with the estimate: 90%); the middle value sits exactly at the limit.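

Within the data shown here, the steps among compound 1, compound 2 and compound 3 cannot be read, so no new step comes from compound 3 in this assay. The picture stays as it was: the limit of > 100000 nM in this assay, at which 3 of the 3 values shown sit. The compounds shown leave open how much compound is tolerated in any of the three, and whether any group on the carbonyl carbon changes this.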